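The compounds below may be only part of what the source reports. "The series", "measured", "known", "first", "only" and "open" are said of these compounds alone.

Of the compounds shown here, two that share a core have been measured in a physicochemical assay for solubility, at pH 2; a higher number here means a more soluble compound, a lower number a less soluble compound. Compound 1 `CCCCNc1nc(NCCCC)c2ccccc2n1` returns a limit of that assay rather than a number, namely >= 30000 nM. Compound 2 `CC(C)Nc1nc(NCc2ccco2)c2ccc(Cl)cc2n1` also returns a limit, namely >= 30000 nM. That is where compound 2 stands: the limit of >= 30000 nM in this assay, at which 2 of the 2 values shown sit. Compound 3 `COc1ccc2c(NCc3ccco3)nc(NC(C)C)nc2c1` has not yet been measured in this assay. It differs from compound 2 in one place, (methoxy in place of chloro on an aromatic carbon), that is, methoxy in place of chloro on an aromatic carbon. Among the compounds with values here, no measured pair in this set isolates such a change, so the measured compounds give no direction for it. The expected step is a number no higher from compound 2 to compound 3 (the limit leaves the size open), which is none beyond the usual scatter. Compound 3 is accordingly estimated at 30000 nM in this assay, with a range from 15000 nM to 60000 nM, and a limit rather than a number is the likely outcome.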

Compound 3, solubility: >= 30000 nM
Compound 3 was reported as a limit; the forecaster's own chance of this, stated with the estimate: 80%; the middle value sits exactly at the limit.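

In this assay, compound 2 and compound 3 both return a limit rather than a number, so no step between them can be read: the limit of >= 30000 nM in this assay, at which 3 of the 3 values shown sit.

The compounds shown leave open whether methoxy in place of chloro on an aromatic carbon changes this read-out at all, and in which direction.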